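The compounds below may be only part of what the source reports. "The series", "measured", "known", "first", "only" and "open" are said of these compounds alone.

Compound 1 `CCOC(=O)[C@@H]1CCCN(S(=O)(=O)c2ccc(C(=O)N(CC)CC)cc2)C1` gives 640 nM in a functional assay on BXPC-3 cells (Homo sapiens) for inhibition, read by MTT assay, with a stated time of 7 days; a higher number here means a weaker inhibitor, a lower number a stronger inhibitor. Compound 2 `CCOC(=O)[C@@H]1CCCN(S(=O)(=O)c2ccc(S(=O)(=O)N3CCNCC3)cc2)C1` gives only a limit of this assay, > 30000 nM. Compound 3 `CCCN(CCC)S(=O)(=O)c1ccc(S(=O)(=O)N2CCC[C@@H](C(=O)OCC)C2)cc1` gives 2500 nM.

Among the two numbers, compound 3 has the highest, the nearest being compound 1, with a 3.9-fold higher number from compound 1 to compound 3 (0.59 log units; beyond the scatter). Compound 4 `CCCN(CC)S(=O)(=O)c1ccc(S(=O)(=O)N2CCC[C@@H](C(=O)OCC)C2)cc1` differs from compound 3 by hydrogen in place of methyl on a saturated chain carbon, two bonds along the chain from a sulfonamide nitrogen. Among the measured compounds shown here, none of the measured steps makes this change: each swaps a whole group on the shared core, as in an at least 12-fold lower number from compound 2 to compound 3 (1.07 log units; beyond the scatter), a large step, and an at least 46-fold higher number from compound 1 to compound 2 (1.67 log units; beyond the scatter), which reaches the limit (the limit of > 30000 nM in this assay, at which 1 of the 3 values shown sits). Those steps therefore say little here. For so small a change, the expected step is no change at the digits printed from compound 3 to compound 4 (within the scatter), within the scatter. Compound 4 is estimated at 2500 nM, likely between 1000 nM and 6000 nM.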

Compound 4, half-maximal inhibitory concentration: 300 nM
Compound 4: the middle estimate sits 8.3-fold (0.92 log units) above what was measured, and the stated range ends above it.
By their numbers in this assay, from the lowest: compound 4; then compound 1; then compound 3. At a limit, above all of these: compound 2.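

Taking a single methyl off the dipropylamino group is enough to move the result, with an 8.3-fold lower number from compound 3 to compound 4 (0.92 log units; beyond the scatter), so this small trim counts for as much as some whole-group swaps among the earlier compounds. It also reverses the order against the amide compound, giving a 2.1-fold lower number from compound 1 to compound 4 (0.33 log units; beyond the scatter). Compound 2 has only a limit, so the step of an at least 100-fold lower number from compound 2 to compound 4 (2.00 log units; beyond the scatter) gives a minimum size, not an exact one.

The compounds shown leave open whether diethylamino or dimethylamino on the sulfonyl sulfur would lower the number further. A ring amine such as piperidine there also remains unread.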